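Nitro for methoxy in a set of low readings

The compounds below may be only part of what the source reports. "The series", "measured", "known", "first", "only" and "open" are said of these compounds alone.

In a functional assay on NCI-H460 cells (Homo sapiens) for inhibition, read by MTT assay, with a stated time of 24 h, tested at 1 ug/mL (a lower number here means less inhibition of growth, a higher number more inhibition of growth at the concentration tested), compound 1 (`O=C(CCCCC(S)CCS)Nc1ccccc1`) gives 4.3% and compound 2 (`O=C(CCCCC(S)CCS)Nc1ccc(Cl)cc1`) gives 6.76% at the single concentration tested. Going by the values given here, compound 3 (`COc1ccc(NC(=O)CCCCC(S)CCS)cc1`) is reported as "not active" (no number reported) and carries no number, so it has no measured step to either of the other two. Compound 4 (`O=C(CCCCC(S)CCS)Nc1ccc([N+](=O)[O-])cc1`) differs from compound 3 in one place, with nitro in place of methoxy on an aromatic carbon. Among the compounds with values here, the only measured step (a number 2.5 percentage points higher from compound 1 to compound 2 (within the scatter)) is a different change, chloro in place of hydrogen on an aromatic carbon, and it bears on this one only indirectly. Within the data shown here, no measured step involves nitro or methoxy, so the data give no direction for the change, and no step beyond the scatter is expected in this assay. Among the measured compounds shown here, a low reading is expected, resting on compound 1 at 4.3% and compound 2 at 6.76% as the only numbers available. Compound 4 is estimated to give about 5%, with an expected range from 0% to 15%.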

Compound 4, percent growth inhibition at one concentration: 4.64%
Estimate against measurement, compound 4: 0.4 percentage points above; the measured number falls inside the stated range.
By their numbers in this assay, from the lowest: compounds 1, 4 and 2 (each within the scatter of the next).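

Nitro at this position, on an aromatic carbon para to a large group, now gives a number in this assay, so it can be set against chloro (a number 2.1 percentage points lower from compound 2 to compound 4 (within the scatter)) and against hydrogen (a number 0.3 percentage points higher from compound 1 to compound 4 (within the scatter)). Both steps lie within the scatter, so hydrogen, chloro and nitro at this position cannot be told apart in this assay. The change from methoxy to nitro cannot itself be read as a step, since compound 3 carries no number, and nothing at hand bears on the cause of these readings.

From the compounds shown here alone, whether any group at this position gives a step beyond the scatter remains open, for instance an amine or a carboxylic acid. Going by these compounds, it is also open whether a change elsewhere on the shared core, such as a longer chain, would move these low readings.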